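The source may hold more compounds than are shown below. What is called first, only, known or untested is meant among the compounds shown, and "the series" means these compounds.

The three measured compounds share one core and differ only in the group on a sulfonyl sulfur. Compound 3 `CCn1cc(C(=O)O)c(=O)c2cc(F)c(N3CCN(C(=N)NS(=O)(=O)c4ccccc4Cl)CC3)cc21` gives 71 nM in a functional assay on A549 cells (Homo sapiens) for antiproliferative activity, read by MTT assay, with a stated time of 72 h; a lower number here means a stronger inhibitor, a higher number a weaker inhibitor. Compound 1 `CCn1cc(C(=O)O)c(=O)c2cc(F)c(N3CCN(C(=N)NS(=O)(=O)c4ccc(C)cc4)CC3)cc21` gives 71 nM and compound 2 `CCn1cc(C(=O)O)c(=O)c2cc(F)c(N3CCN(C(=N)NS(=O)(=O)c4cccc(Cl)c4)CC3)cc21` gives 71 nM, so compound 3 stands level with both at the digits shown. The steps among them were no change at the digits printed from compound 1 to compound 2 (within the scatter), no change at the digits printed from compound 1 to compound 3 (within the scatter) and no change at the digits printed from compound 2 to compound 3 (within the scatter). Compound 4 `CCn1cc(C(=O)O)c(=O)c2cc(F)c(N3CCN(C(=N)NS(=O)(=O)c4ccc(Cl)cc4)CC3)cc21` differs from compound 3 by 4-chlorophenyl in place of 2-chlorophenyl on a sulfonyl sulfur. All three measured steps exchanged one group for another on a sulfonyl sulfur, and each stayed within the scatter, which bears directly on this further exchange at the same place. A fourth such exchange is therefore expected to leave this assay unmoved beyond the scatter, in neither direction. The expected step is no change at the digits printed from compound 3 to compound 4 (within the scatter). Compound 4 is estimated at 71 nM, with a range from 35 nM to 145 nM. Among the compounds with values here, no measured compound carries the 4-chlorophenyl group itself, so this expectation rests on compounds 1, 2 and 3 alone.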

Compound 4, half-maximal inhibitory concentration: 71 nM
Beside the measured number, compound 4's estimate shows no gap at the digits printed; the measured number falls inside the stated range.
By their numbers in this assay, from the lowest: compounds 1, 2, 3 and 4 (each within the scatter of the next).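

With compound 4, the three chlorophenyl groups on the sulfonyl sulfur can all be compared in this assay: 4-chlorophenyl in place of 2-chlorophenyl gives no change at the digits printed from compound 3 to compound 4 (within the scatter), and 4-chlorophenyl in place of 3-chlorophenyl gives no change at the digits printed from compound 2 to compound 4 (within the scatter). The series also now holds a single exchange of the substituent itself, chloro in place of methyl on an aromatic carbon, which gives no change at the digits printed from compound 1 to compound 4 (within the scatter). No measurement offered here explains why these exchanges leave the assay unmoved.

Going by these compounds, the four compounds all carry a substituted phenyl group on the sulfonyl sulfur, so the effect of an unsubstituted phenyl, a methoxyphenyl or a butyl chain there remains open. Whether the same exchanges would stay within the scatter on a different core is also unresolved.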